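Changing the Aryl Group on a Shared Hydrazone Core

The compounds below may be only part of what the source reports. "The series", "measured", "known", "first", "only" and "open" are said of these compounds alone.

The measured compounds:
compound 1, `CSc1nn(-c2ccccc2)c2ncnc(N/N=C/c3ccc(Br)cc3)c12`, which in a functional assay on MCF7 cells (Homo sapiens) for inhibition, read by sulforhodamine B assay, with a stated time of 48 h (a lower number here means a stronger inhibitor, a higher number a weaker inhibitor), gives 10.9 nM
compound 2, `COc1cccc(/C=N/Nc2ncnc3c2c(SC)nn3-c2ccccc2)c1`, which in this assay gives 11.1 nM

Both compounds share the same core and differ only in the aryl group carried on a carbon with a double bond to nitrogen. The step of a 1.0-fold higher number from compound 1 to compound 2 (0.01 log units; within the scatter) shows that compound 1 and compound 2 sit together; neither can be called the stronger inhibitor on these numbers.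

Compound 3, `CSc1nn(-c2ccccc2)c2ncnc(N/N=C/c3ccc([N+](=O)[O-])cc3Cl)c12`, is the next member and has not yet been measured. Compared with compound 2 the change is 2-chloro-4-nitrophenyl in place of 3-methoxyphenyl on a carbon with a double bond to nitrogen. Among the compounds with values here, the only measured step that bears on it is the one swapping the aryl group, a 1.0-fold higher number from compound 1 to compound 2 (0.01 log units; within the scatter), and it stayed within the scatter. With nothing further to go on, the expected step of a 1.1-fold higher number from compound 2 to compound 3 (0.03 log units; within the scatter) is none beyond the scatter, in no particular direction. Compound 3 is therefore estimated to give 12 nM in this assay, expected to fall between 5 nM and 30 nM.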

Compound 3, half-maximal inhibitory concentration: 15.7 nM
For compound 3 the middle estimate is 1.3-fold (0.12 log units) below the measured one; the measured number falls inside the stated range.
By their numbers in this assay, from the lowest: compounds 1, 2 and 3 (each within the scatter of the next).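

Placing 2-chloro-4-nitrophenyl on the carbon with a double bond to nitrogen gives a 1.4-fold higher number from compound 2 to compound 3 (0.15 log units; within the scatter) and a 1.4-fold higher number from compound 1 to compound 3 (0.16 log units; within the scatter), so in this assay compound 3 cannot be told apart from either earlier compound. The earlier pair compared only a ring bearing bromine with one bearing methoxy, whereas this result extends the same finding to a ring bearing both chlorine and a nitro group, so three differently substituted phenyl rings at this position now give numbers within the scatter of one another. No measurement at hand explains why these aryl swaps leave the number within the scatter.

Going by these compounds, all three compounds carry a six-membered aromatic ring of carbon only at this position, so it remains open whether the number would hold with that ring replaced by a simple alkyl chain, or with a phenyl ring bearing an amine or a carboxylic acid. Because the shared core is the same throughout and every step lies within the scatter, the compounds also leave open what a change elsewhere on that core would do, and whether any group at this position would give a step beyond the scatter.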